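Aryl swap on the shared core: compound 3 to compound 4

The source may report more compounds than this note shows. Statements on the series, on what has been measured and on what is new or still open speak of the compounds shown alone.

Compound 3 `Clc1cccc(N2CCN(CCCCn3cc(-c4ccc5ccccc5c4)nn3)CC2)c1Cl` gives > 1000 nM in an assay on HEK293 cells for displacement of a labelled ligand from D(4) dopamine receptor (Homo sapiens), read by scintillation counting, with a stated time of 1 h (on this read-out lower numbers stand for stronger inhibition and higher numbers for weaker inhibition), a limit of the assay. Compound 2 `OC(CCn1cc(-c2ccc3ccccc3c2)nn1)CN1CCN(c2cccc(Cl)c2Cl)CC1` gives > 20000 nM in this assay, also a limit. The step that the two limits leave unreadable from compound 2 to compound 3 therefore has no readable size. Compound 1 `OC(CCn1cc(-c2ccc3ncccc3c2)nn1)CN1CCN(c2cccc(Cl)c2Cl)CC1` stands as "not determined" (no result reported) in this assay. The change from compound 3 to compound 4 `Clc1cccc(N2CCN(CCCCn3cc(-c4ccc5ncccc5c4)nn3)CC2)c1Cl` is quinolin-6-yl in place of naphthalen-2-yl on an aromatic carbon. Going by the values given here, no measured step bears on this change: compound 1, which carries the same group as compound 4, has no result, and the two values that exist sit at the limit of > 1000 nM in this assay, at which 1 of the 3 values shown sits, and (the limit of > 20000 nM in this assay, at which 1 of the 3 values shown sits), so no size or direction can be derived. Compound 4 is expected to sit near 3000 nM in this assay, within 500 nM to 20000 nM, most likely again reported as a limit. This estimate means a step that the limit leaves unreadable from compound 3 to compound 4 expected to stay within the scatter.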

Compound 4, inhibition constant: > 1000 nM
Compound 4: no number, only a limit; the forecaster's own chance of this, stated with the estimate: 60%; the middle value does not contradict the limit.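

Compound 3 and compound 4 yield no readable step, since both sit at the same limit: the limit of > 1000 nM in this assay, at which 2 of the 4 values shown sit.

The compounds shown leave open whether quinolin-6-yl and naphthalen-2-yl differ in this assay at all.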